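The source may report more compounds than this note shows. Statements on the series, on what has been measured and on what is new or still open speak of the compounds shown alone.

Three compounds of the series have values in an ADME assay (liver) for metabolic stability, with Liver microsome (Rattus norvegicus) as the target, read by LC-MS, using microsomes, with a stated time of 30 min, tested at 4 uM; a lower number here means that less of the compound is left, a higher number that more of the compound is left. Compound 1 `COCCn1c(-c2ccccc2Cl)nc2c(N3CCN4C(=O)CCC4C3)nc(C)nc21` gives 91%, and compound 2 `CC(=O)NCCn1c(-c2ccccc2Cl)nc2c(N3CCN(C)CC3)nc(C)nc21` gives 0%. Compound 3 `COc1ccccc1-c1nc2c(N3CCN(C)CC3)nc(C)nc2n1C1CCOCC1` gives 35%, the second highest of the three, with its gaps to both of the others beyond the scatter.

Compound 4 `CCc1ccccc1-c1nc2c(N3CCN(C)CC3)nc(C)nc2n1C1CCOCC1` differs from compound 3 in one place: ethyl in place of methoxy on an aromatic carbon. This is ethyl in place of methoxy on an aromatic carbon, ortho to a large group.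

Among the compounds with values here, no two measured compounds differ in only one place, so the series offers no direct precedent for this change in this assay. The wide spread of the three values cannot be assigned to any single group. The starting point therefore remains compound 3 at 35%. A small downward step is expected, a number 7 percentage points lower from compound 3 to compound 4 (within the scatter), and it is not expected to lie beyond the scatter. The uncertainty is wide in both directions. The estimate for compound 4 is 28%, with an expected range from 10% to 50%.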

Compound 4, percent of the compound remaining: 51%
Compound 4: the middle estimate sits 23 percentage points below what was measured; the measured number lies above the stated range.
By their numbers in this assay, from the lowest: compound 2; then compound 3; then compound 4; then compound 1.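

In this assay, within the data shown here, the change of methoxy to ethyl on an aromatic carbon, ortho to a large group, gives a number 16 percentage points higher from compound 3 to compound 4 (beyond the scatter), and this is the only comparison that differs in one place. This position therefore affects the read-out, with the rest of the structure held constant. The exchange removes one oxygen and one hydrogen-bond acceptor while keeping two heavy atoms, but the available data offer no measured explanation for the step.

Going by these compounds, whether a longer chain such as propyl, or a nitrile or trifluoromethyl group, at this place would continue the trend remains open. On these data alone, it is also open whether the same exchange would give a comparable step with a different group on the shared core.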